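The source may report more compounds than this note shows. Statements on the series, on what has been measured and on what is new or still open speak of the compounds shown alone.

Measured in a functional assay on SK-MEL-5 cells (Homo sapiens) for inhibition; a lower number here means a stronger inhibitor of growth, a higher number a weaker inhibitor of growth:

- compound 1 `NC(=O)c1cc(Cl)ccc1NC(=O)COc1ccccc1`: 7450 nM
- compound 2 `NC(=O)c1cc(I)ccc1NC(=O)COc1ccccc1`: 533 nM

Compound 2 has the lower of the two numbers, which makes it the stronger inhibitor of growth so far. Within the data shown here, the only measured step, a 14-fold lower number from compound 1 to compound 2 (1.15 log units; beyond the scatter), puts iodo in place of chloro on an aromatic carbon. It is large and beyond the scatter, so the group at this place on the shared core can matter a great deal in this assay.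

Compound 3 `COc1ccc(NC(=O)COc2ccccc2)c(C(N)=O)c1` changes that same place again, with methoxy in place of iodo on an aromatic carbon. The new group sits on an aromatic carbon, meta to a carbamoyl group and para to a large group. Among the measured compounds shown here, no measured compound carries methoxy, so this expectation rests on one step alone. For the measured compounds named here, the low number has so far been seen only with iodo, while chloro in compound 1 gives 7450 nM. A clear rise is therefore expected on losing iodo, probably somewhat smaller than the measured step. The expected change is a 7.5-fold higher number from compound 2 to compound 3 (0.88 log units; beyond the scatter). For compound 3 the estimated value is 4000 nM, within an expected range of 1200 nM to 15000 nM.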

Compound 3, concentration for 50% growth inhibition: 1680 nM
Compound 3: middle estimate off by 2.4-fold (0.38 log units), on the high side; the range from low to high includes it.
By their numbers in this assay, from the lowest: compound 2; then compound 3; then compound 1.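

In this assay the change from iodo to methoxy costs only part of what iodo gained over chloro, with a modest step (a 3.2-fold higher number from compound 2 to compound 3 (0.50 log units; beyond the scatter)). The same methoxy group still improves on chloro, again by a modest step (a 4.4-fold lower number from compound 1 to compound 3 (0.65 log units; beyond the scatter)), so compound 3 sits between the two halogen compounds, and each of the three groups at this place gives its own level beyond the scatter. The low number is therefore not tied to iodo alone and does not simply separate halogens from non-halogens, although nothing available explains this order.

On these data alone, three groups cannot show what sets the order, so it remains open how bromo, which would complete the halogen series with chloro and iodo, or a longer chain such as ethoxy would compare at this place. Also open, as far as these compounds go, is whether an amine or a carboxylic acid would be tolerated here, and whether the ranking of iodo, methoxy and chloro would hold if another part of the shared core were changed.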